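The source may report more compounds than this note shows. Statements on the series, on what has been measured and on what is new or still open speak of the compounds shown alone.

Four compounds share one core and differ only in the group attached to the saturated six-membered ring. Compound 1 `CCCn1c(=O)[nH]c2nc(-c3ccc(S(=O)(=O)N4CCN(c5ccc(Cl)cc5F)CC4)cc3)[nH]c2c1=O` gives 14% in an assay on CHO cells for displacement of a labelled ligand from adenosine receptor A3 (Homo sapiens), read by scintillation counting, with a stated time of 45 min, tested at 1 uM, in the presence of a further agent that is not named here; on this read-out lower numbers stand for less inhibition and higher numbers for more inhibition at the one concentration tested (going by the name of the read-out). In this assay, within the data shown here, compound 2 `CCCn1c(=O)[nH]c2nc(-c3ccc(S(=O)(=O)N4CCN(c5ccc(C)cc5)CC4)cc3)[nH]c2c1=O` gives 25%; the one measured single-place step, a number 11 percentage points higher from compound 1 to compound 2 (beyond the scatter), is modest and concerns the phenyl group on the ring nitrogen. Compound 3 `CCCn1c(=O)[nH]c2nc(-c3ccc(S(=O)(=O)N4CCN(c5ccccc5)C(C)C4)cc3)[nH]c2c1=O` stands lowest of the three: in this assay compound 3 gives -2%, a number beyond the scatter below compound 1 and further still below compound 2.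

Compound 4 `CCCn1c(=O)[nH]c2nc(-c3ccc(S(=O)(=O)N4CCN(c5ccccc5)CC4)cc3)[nH]c2c1=O` is reached from compound 3 by one change: hydrogen in place of methyl on a saturated ring carbon. Among the measured compounds shown here, no measured step touches this ring carbon, so nothing among the measured pairs tells directly how removing the methyl changes the read-out. Compound 1 and compound 2 carry no methyl there, but their phenyl groups also differ from that of compound 4, so their numbers do not isolate this change. With only weak guidance, a small upward step is expected rather than a large one. The step of a number 12 percentage points higher from compound 3 to compound 4 (beyond the scatter) is therefore estimated to be small and close to the scatter. Compound 4 is expected to give about 10% in this assay, with a likely range from -8% to 28%.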

Compound 4, a percentage reported as inhibition, at one concentration (the size of the read-out at that concentration, not a potency): 27%
Compound 4: the middle estimate sits 17 percentage points below what was measured, and the stated range covers the measured number.
By their numbers in this assay, from the lowest: compound 3; then compound 1; then compounds 2 and 4 (each within the scatter of the next).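

Among these compounds, replacing the methyl on the saturated ring carbon with hydrogen gives a number 29 percentage points higher from compound 3 to compound 4 (beyond the scatter) in this assay, the first direct reading of this position, and it shows that this single carbon atom separates a compound with no measurable inhibition from one of the higher readings in the set. The same exchange of hydrogen for methyl on an aromatic carbon gives only a number 2 percentage points higher from compound 2 to compound 4 (within the scatter), so among these compounds the methyl matters on the saturated ring carbon but not detectably on the phenyl group, while phenyl in place of 4-chloro-2-fluorophenyl on the ring nitrogen gives a number 13 percentage points higher from compound 1 to compound 4 (beyond the scatter). Nothing at hand explains why the methyl on the saturated ring carbon has this effect on the read-out.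

The compounds shown leave open whether an ethyl, a hydroxymethyl or a fluorine on this same ring carbon would read like the methyl or like the hydrogen. They also leave open whether a methyl on one of the other saturated ring carbons would give a similar drop, and a reading at one concentration gives no potency for any of these compounds.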